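A few compounds are considered here, and "the series" means these few. Any claim that something is new, unique, unknown or untested is made for them only; others in the source may bear on it.

Measured compounds:
- Compound 1, `C[C@H](NC(=O)CN(c1nc(Cl)nc2[nH]cnc12)C1CC1)C(=O)OCc1ccccc1`: 23%
- Compound 2, `C[C@@H](O)[C@H](NC(=O)CN(c1nc(Cl)nc2[nH]cnc12)C1CC1)C(=O)OCc1ccccc1`: 12.8%
- Compound 3, `CC[C@H](C)[C@H](NC(=O)CN(c1nc(Cl)nc2[nH]cnc12)C1CC1)C(=O)OCc1ccccc1`: 6.9%

These three compounds share one core and differ only in the group on a saturated chain carbon bound to an amide-type nitrogen and a carbonyl carbon. In a functional assay on the whole organism (Tail, strain ICR) with Mus musculus as the target, in the tail flick test, with a stated time of 150 min, at a dose of 25 umol/kg by the oral route (a lower number here means a weaker effect, a higher number a stronger effect of the compound at the dose given), compound 1 gives 23%. Replacing its methyl with 1-hydroxyethyl gives a number 10.2 percentage points lower from compound 1 to compound 2 (beyond the scatter), and replacing it with sec-butyl gives a number 16.1 percentage points lower from compound 1 to compound 3 (beyond the scatter). Between compound 2 and compound 3 the step is a number 5.9 percentage points lower from compound 2 to compound 3 (within the scatter), so these two cannot be told apart. Compound 3 therefore has the lowest number of the three, separated beyond the scatter only from compound 1.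

Compound 4, `CC(C)C[C@H](NC(=O)CN(c1nc(Cl)nc2[nH]cnc12)C1CC1)C(=O)OCc1ccccc1`, is to be measured. The change from compound 3 is isobutyl in place of sec-butyl on a saturated chain carbon bound to an amide-type nitrogen and a carbonyl carbon. Within the data shown here, no measured step swaps two four-carbon groups against each other; the steps seen so far only show that enlarging the methyl lowers the read-out. Since compound 4 keeps a four-carbon group in the same place, the expected step is small: a number 2.1 percentage points higher from compound 3 to compound 4 (within the scatter), within the scatter. For compound 4 the estimated value is 9%, with a range from 0% to 22%.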

Compound 4, a percentage reported as activity, at one dose (the size of the read-out at that dose, not a potency): 5.26%
Estimate against measurement, compound 4: 3.7 percentage points above, within the range that was stated.
By their numbers in this assay, from the lowest: compounds 4, 3 and 2 (each within the scatter of the next); then compound 1.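

In this assay, isobutyl in place of sec-butyl gives a number 1.6 percentage points lower from compound 3 to compound 4 (within the scatter) and so the two four-carbon groups cannot be told apart at this position, even though the defined stereocentre of sec-butyl is gone. Isobutyl in place of 1-hydroxyethyl gives a number 7.5 percentage points lower from compound 2 to compound 4 (within the scatter) and again separates nothing. Set against methyl, the result is a number 17.7 percentage points lower from compound 1 to compound 4 (beyond the scatter) and so all three larger groups shown now stand apart from methyl, while none of them can be told apart from the next in the order of their numbers.

Nothing measured here explains why these groups read as they do. Still open, from the compounds shown here alone, is how a plain hydrogen, a benzyl group or a chain carrying an amine would read at this position.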